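A few compounds are considered here, and "the series" means these few. Any claim that something is new, unique, unknown or untested is made for them only; others in the source may bear on it.

Compound 1 `COc1ncnc2c1c(-c1ccsc1)cn2[C@@H]1O[C@H](CO)[C@@H](O)[C@H]1O` gives 3350 nM in a functional assay on HeLa S3 cells (Homo sapiens) for antiproliferative activity, read by XTT assay, with a stated time of 72 h; a higher number here means a weaker inhibitor, a lower number a stronger inhibitor.
Compound 2 `COc1ncnc2c1c(I)cn2[C@@H]1O[C@H](CO)[C@@H](O)[C@H]1O` gives 14300 nM in this assay.
Compound 3 `COc1nc(N)nc2c1c(-c1ccco1)cn2[C@@H]1O[C@H](CO)[C@@H](O)[C@H]1O` gives only a limit of the assay, > 20000 nM in this assay.

Of the three measured compounds, compound 3 is the one that stands at the limit rather than at a number, the limit being (the limit of > 20000 nM in this assay, at which 1 of the 3 values shown sits). Compound 1, which carries a thiophen-3-yl group and no amino group, gives a number well inside the measured range, whereas compound 3 carries a furan-2-yl group together with an amino group.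

Among the compounds with values here, the only measured step, a 4.3-fold higher number from compound 1 to compound 2 (0.63 log units; beyond the scatter), concerns the group on the five-membered ring and leaves the amino position untouched, so no measured step bears directly on the change considered here.

Compound 4 `COc1ncnc2c1c(-c1ccco1)cn2[C@@H]1O[C@H](CO)[C@@H](O)[C@H]1O` differs from compound 3 by hydrogen in place of amino on an aromatic carbon. Compound 4 thus shares with compound 1 the absence of an amino group. On that resemblance, compound 4 is expected to give about 4500 nM in this assay, within a range from 1500 nM to 15000 nM. That expectation would mean a step of an at least 4.4-fold lower number from compound 3 to compound 4 (0.64 log units; beyond the scatter) away from the limit, though the uncertainty is wide.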

Compound 4, half-maximal inhibitory concentration: 1020 nM
The estimate for compound 4 lay 4.4-fold (0.64 log units) above the measured number; measured number outside the range, below it.
By their numbers in this assay, from the lowest: compound 4; then compound 1; then compound 2. At a limit, above all of these: compound 3.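

In this assay, within the data shown here, hydrogen in place of amino on the aromatic carbon between two ring nitrogen atoms gives an at least 19-fold lower number from compound 3 to compound 4 (1.29 log units; beyond the scatter), the first measured change at this position. That step has only a lower bound, as compound 3 stands at a limit of the assay and not at a number: the limit of > 20000 nM in this assay, at which 1 of the 4 values shown sits. With no amino group present, the aromatic carbon bearing the other varied group also shows a clear order, as furan-2-yl in place of iodo gives a 14-fold lower number from compound 2 to compound 4 (1.15 log units; beyond the scatter) and furan-2-yl in place of thiophen-3-yl gives a 3.3-fold lower number from compound 1 to compound 4 (0.52 log units; beyond the scatter).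

As far as these compounds go, it remains open whether a methylamino group or a chlorine atom at the position between the two ring nitrogen atoms would fall nearer to compound 4 or to compound 3. The amino change is shown only with furan-2-yl, so its size with thiophen-3-yl or iodo also remains open.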